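The source may hold more compounds than are shown below. What is called first, only, known or untested is meant among the compounds shown, and "the series" means these compounds.

The measured compounds:
Compound 1, `O=C1C(NC2CC2)=CC(=O)c2c1nc1n2[C@H]2OC[C@@H](O)[C@H]2OC1`, in a functional assay on HeLa cells (Homo sapiens) for inhibition, read by sulforhodamine B assay (a higher number here means a weaker inhibitor, a lower number a stronger inhibitor), gives > 16000 nM, which is a limit of the assay and not a number.
Compound 2, `CCOc1ccccc1NC1=CC(=O)c2c(nc3n2[C@H]2OC[C@@H](O)[C@H]2OC3)C1=O`, in this assay gives 8300 nM.
Compound 3, `Cc1ccc(NC2=CC(=O)c3c(nc4n3[C@H]3OC[C@@H](O)[C@H]3OC4)C2=O)cc1`, in this assay gives 6590 nM.

Compound 3 has the lowest of the two numbers that were obtained, but compound 2 is its nearest neighbour and the step of a 1.3-fold lower number from compound 2 to compound 3 (0.10 log units; within the scatter) lies within the scatter, so the two cannot be told apart. The steps of an at least 1.9-fold lower number from compound 1 to compound 2 (0.28 log units; that floor lies within the scatter) and an at least 2.4-fold lower number from compound 1 to compound 3 (0.38 log units; beyond the scatter) are only floors, set by the limit of > 16000 nM in this assay, at which 1 of the 3 values shown sits, so they show that both aryl groups on the amine nitrogen do better than cyclopropyl, without saying by how much.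

Compound 4, `O=C1C(Nc2ccc(C(F)(F)F)cc2)=CC(=O)c2c1nc1n2[C@H]2OC[C@@H](O)[C@H]2OC1`, differs from compound 3 by trifluoromethyl in place of methyl on an aromatic carbon. Within the data shown here, none of the measured steps touches a group on this aromatic ring: each of them swaps the whole group on the amine nitrogen. Among the measured compounds shown here, no measured step therefore bears on this change, and there is nothing in the numbers to point in either direction. The expectation is a step of a 1.1-fold lower number from compound 3 to compound 4 (0.04 log units; within the scatter) in this assay, that is, none beyond the scatter. Compound 4 is estimated at 6000 nM in this assay, with a range from 2500 nM to 15000 nM.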

Compound 4, half-maximal inhibitory concentration: 8920 nM
Beside the measured number, compound 4's estimate is 1.5-fold (0.17 log units) below it; the range from low to high includes it.
By their numbers in this assay, from the lowest: compounds 3, 2 and 4 (each within the scatter of the next). At a limit, above all of these: compound 1.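

Trifluoromethyl in place of methyl, on the aromatic carbon para to a large group, is the first change shown on the aromatic ring itself rather than a swap of the whole group on the amine nitrogen. In this assay the step is a 1.4-fold higher number from compound 3 to compound 4 (0.13 log units; within the scatter), so this position tolerates the exchange as far as this assay can tell. The steps of a 1.1-fold higher number from compound 2 to compound 4 (0.03 log units; within the scatter) and a 1.3-fold lower number from compound 2 to compound 3 (0.10 log units; within the scatter) add that 2-ethoxyphenyl, 4-methylphenyl and 4-(trifluoromethyl)phenyl on the amine nitrogen cannot be told apart here. Compound 1 gives only a limit of the assay. The step of an at least 1.7-fold lower number from compound 1 to compound 4 (0.25 log units; that floor lies within the scatter) is therefore only a floor and cannot be read as a size: the limit of > 16000 nM in this assay, at which 1 of the 4 values shown sits.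

The compounds shown carry only methyl and trifluoromethyl at this spot, so what an amine, a carboxylic acid or a longer chain would do there remains open. Also open, as far as these compounds go, is whether any group on this ring can move the number beyond the scatter at all, since the two groups compared here give no sign of which way such a change would run.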